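Chloro in Place of Methyl on the Shared Core

The source may report more compounds than this note shows. Statements on the series, on what has been measured and on what is new or still open speak of the compounds shown alone.

Compound 1 `Cc1ccc(NC(=S)NC(=O)c2ccc(OCc3ccc(C(F)(F)F)cc3)cc2)cc1-c1nc2ccccc2[nH]1` gives 72400 nM in a functional assay on SW-620 cells (Homo sapiens) for inhibition, read by MTT assay, with a stated time of 48 h (a higher number here means a weaker inhibitor, a lower number a stronger inhibitor), the highest of the three measured numbers. Compound 2 `Cc1ccc(NC(=S)NC(=O)c2ccc(OCc3ccccc3F)cc2)cc1-c1nc2ccccc2[nH]1` gives 6440 nM in this assay, and compound 3 `Cc1ccc(NC(=S)NC(=O)c2ccc(OCc3ccc(Cl)cc3Cl)cc2)cc1-c1nc2ccccc2[nH]1` gives 57200 nM. The measured steps, an 11-fold lower number from compound 1 to compound 2 (1.05 log units; beyond the scatter) and a 1.3-fold lower number from compound 1 to compound 3 (0.10 log units; within the scatter), both change the group on the saturated chain carbon bound to the oxygen, not the part of the core altered here. Compound 4 `O=C(NC(=S)Nc1ccc(Cl)c(-c2nc3ccccc3[nH]2)c1)c1ccc(OCc2ccc(C(F)(F)F)cc2)cc1` differs from compound 1 by chloro in place of methyl on an aromatic carbon. Within the data shown here, no measured step touches this position, so no step beyond the scatter is expected, and the change is estimated as a 1.0-fold lower number from compound 1 to compound 4 (0.01 log units; within the scatter). Compound 4 is therefore expected to give about 70000 nM in this assay, with a range from 25000 nM to 200000 nM.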

Compound 4, half-maximal inhibitory concentration: 63900 nM
For compound 4 the middle estimate is 1.1-fold (0.04 log units) above the measured one, within the range that was stated.
By their numbers in this assay, from the lowest: compound 2; then compounds 3, 4 and 1 (each within the scatter of the next).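

In this assay chloro in place of methyl, ortho to a 1H-benzimidazol-2-yl group, brings a 1.1-fold lower number from compound 1 to compound 4 (0.05 log units; within the scatter) and so leaves the reading of compound 1 unchanged within the scatter. Among these compounds, this is the first measured change on the shared core, as the earlier steps all changed the group on the chain carbon bound to the oxygen. Nothing measured here explains why the two groups read alike.

Still open, as far as these compounds go, is how an amine or a carboxylic acid would read at this position. Also open, from the compounds shown here alone, is whether chloro would read the same with the 2-fluorophenyl group of compound 2.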